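This account rests on a few compounds, and the source may have more. Where it says the series, first, only, none or still open, it means among the compounds named here.

Compound 1 `COc1cc(N)c(Cl)cc1C(=O)NCC1CCNCC1` gives 316 nM in an assay on HEK293 cells for displacement of a labelled ligand from 5-hydroxytryptamine receptor 4 (Homo sapiens), read by scintillation counting; a higher number here means a weaker inhibitor, a lower number a stronger inhibitor. Compound 2 `CC(C)n1c(=O)n(C(=O)NCC2CCNCC2)c2ccccc21` gives 39.8 nM. Compound 3 `COc1cc(N)c(Cl)cc1C(=O)NC1CCN(CCCCCN2C(=O)c3ccccc3C2=O)CC1` gives 20 nM.

Of the three numbers, that of compound 3 is the smallest, but compound 2 lies within the scatter of it, so the two cannot be told apart; only compound 1 stands clearly apart, with its larger number. Compound 4 `COc1cc(N)c(Cl)cc1C(=O)NC1CCN(CCCCCCCCN2CCCCC2)CC1` differs from compound 3 by a group of 9 heavy atoms (8 carbon, 1 nitrogen; one six-membered non-aromatic ring with 1 hetero atom) in place of a group of 11 heavy atoms (8 carbon, 1 nitrogen, 2 oxygen; one five-membered non-aromatic ring with 1 hetero atom, one six-membered aromatic ring of carbon only), on a saturated chain carbon, five bonds along the chain from an amine nitrogen in a ring. For the measured compounds named here, no measured pair shows this change, so there is no step to lean on. The step expected here is a 1.3-fold lower number from compound 3 to compound 4 (0.12 log units; within the scatter), small and in no settled direction, not beyond the scatter. Compound 4 is therefore estimated at 15 nM, with a range from 4 nM to 60 nM.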

Compound 4, inhibition constant: 3.16 nM
Estimate against measurement, compound 4: 4.7-fold (0.68 log units) above, outside the stated range (below it).
By their numbers in this assay, from the lowest: compound 4; then compounds 3 and 2 (each within the scatter of the next); then compound 1.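

In this assay, 3-(piperidin-1-yl)propyl on the saturated chain carbon, five bonds along the chain from an amine nitrogen in a ring, gives a 6.3-fold lower number from compound 3 to compound 4 (0.80 log units; beyond the scatter) and so shows that this position accepts a group with no aromatic ring and no oxygen without any loss. For the compounds shown here, this single pair is the only reading at this position. Nothing here accounts for the step.

As far as these compounds go, whether the nitrogen of the entering group matters remains open, as a cyclohexyl group on the same chain would test. From the compounds shown here alone, whether a morpholine ring would serve equally is also open.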